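The compounds below may be only part of what the source reports. "The series", "measured", "known", "first", "only" and "open" are said of these compounds alone.

Measured so far:
Compound 1 `Cc1ccc(C2=Nn3c(nnc3C(C)c3ccc(-c4ccccc4)c(F)c3)SC2)cc1` gives 4800 nM in a functional assay on HCT-116 cells (Homo sapiens) for inhibition, read by sulforhodamine B assay, with a stated time of 72 h; a higher number here means a weaker inhibitor, a lower number a stronger inhibitor.
Compound 2 `CC(C)Cc1ccc(C(C)c2nnc3n2N=C(c2ccc(C(F)(F)F)cc2)CS3)cc1` gives 6500 nM in this assay.

The two numbers lie within the scatter of each other, so compound 2 and compound 1 cannot be told apart on what has been measured. Compound 3 `Cc1ccc(C2=Nn3c(nnc3C(C)c3ccc(CC(C)C)cc3)SC2)cc1` is not yet measured. It differs from compound 2 in one place: methyl in place of trifluoromethyl on an aromatic carbon. Compound 1 already carries the same methyl-bearing ring as compound 3, and in this assay compound 1 gives 4800 nM, while in this assay compound 2 gives 6500 nM; with two values this close, no direction can be read from them. Going by the values given here, no step between measured compounds is known for this change. The account therefore expects no step beyond the scatter, a 1.2-fold lower number from compound 2 to compound 3 (0.07 log units; within the scatter). The estimate for compound 3 is 5500 nM, with a range from 2500 nM to 12000 nM.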

Compound 3, half-maximal inhibitory concentration: 4000 nM
Compound 3: the middle estimate sits 1.4-fold (0.14 log units) above what was measured, and the stated range covers the measured number.
By their numbers in this assay, from the lowest: compounds 3, 1 and 2 (each within the scatter of the next).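

The one comparison shown that changes only this position, 4-(trifluoromethyl)phenyl to 4-methylphenyl, gives a 1.6-fold lower number from compound 2 to compound 3 (0.21 log units; within the scatter) in this assay, so the two groups cannot be told apart here. On an aromatic carbon para to a large group, replacing the four heavy atoms of trifluoromethyl with the single carbon of methyl therefore leaves no readable difference in this cell assay, something compound 1 and compound 2 could not show, as they differ in more than one place. No supporting evidence bears on why this position tolerates the change.

From the compounds shown here alone, it remains open whether a group of another kind at this position, such as a carboxylic acid, an amine or a nitrile, would move the number beyond the scatter. Going by these compounds, the same change on a different background, such as the other side of the core in compound 1, also remains untested here.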